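The source may hold more compounds than are shown below. What is called first, only, known or untested is meant among the compounds shown, and "the series" means these compounds.

In a functional assay on A549 cells (Homo sapiens) for antiproliferative activity, read by MTT assay, with a stated time of 48 h (on this read-out lower numbers stand for stronger inhibition and higher numbers for weaker inhibition), compound 1 `CN1CCN(CCn2c(N)c(-c3nc4ccccc4[nH]3)c3nc(C#N)c(C#N)nc32)CC1` gives 40500 nM. Compound 2 `N#Cc1nc2c(-c3nc4ccccc4[nH]3)c(N)n(CCCO)c2nc1C#N` stands at the limit of > 50000 nM in this assay, at which 1 of the 2 values shown sits. Going by these compounds, its reading of > 50000 nM is a limit and not a number, so its true position is unknown.

Compound 3 `CCN(CC)CCCCn1c(N)c(-c2nc3ccccc3[nH]2)c2nc(C#N)c(C#N)nc21` has not yet been measured. It shares the core of compound 2 but carries a different side chain: (diethylamino)methyl in place of hydroxy on a saturated chain carbon, three bonds along the chain from an aromatic nitrogen. Put another way, 3-hydroxypropyl gives way to 4-(diethylamino)butyl.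

Within the data shown here, one measured step bears on this change: an at least 1.2-fold higher number from compound 1 to compound 2 (0.09 log units; that floor lies within the scatter), where hydroxymethyl replaces 4-methylpiperazin-1-yl. That step also trades a chain ending in an amine for one ending in hydroxy, but in the opposite direction to the new change. Since it gives only a floor, it fixes no size. Among the measured compounds shown here, compound 1, at 40500 nM, is the only measured compound with an amine-bearing chain, and it suggests a modest move towards a lower number in this assay. The expected change is an at least 1.6-fold lower number from compound 2 to compound 3 (0.22 log units; that floor lies within the scatter). For compound 3, the estimated value is 30000 nM, with an expected range of 10000 nM to 50000 nM.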

Compound 3, half-maximal inhibitory concentration: 5750 nM
Compound 3: middle estimate off by 5.2-fold (0.72 log units), on the high side; measured number outside the range, below it.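

In this assay, compound 2 has a limit of the assay and not a number: the limit of > 50000 nM in this assay, at which 1 of the 3 values shown sits.

Even so, replacing 3-hydroxypropyl with 4-(diethylamino)butyl gives an at least 8.6-fold lower number from compound 2 to compound 3 (0.93 log units; beyond the scatter), so this side chain can move the read-out by more than the scatter, something the earlier step, with its floor inside the scatter, could not show. An amine at the end of the chain is not enough on its own to give this result: 2-(diethylamino)ethyl in place of 4-methylpiperazin-1-yl, cut one bond further out, gives a 7.0-fold lower number from compound 1 to compound 3 (0.85 log units; beyond the scatter).

The compounds shown leave open how much of the change belongs to the diethylamino end and how much to the length of the chain, as the side chain of compound 3 differs from those of compound 1 and compound 2 in both respects. A 4-hydroxybutyl chain and a 2-(diethylamino)ethyl chain on the shared core would help to separate the two, and a pyrrolidine or morpholine at the end of the butyl chain would test whether the diethylamino group itself matters.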